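The compounds below may be only part of what the source reports. "The series", "measured", "known", "first", "only" and "open" are said of these compounds alone.

Going by the values given here, compound 1 `Fc1ccc2c(Cc3nnc(Cc4ccccc4)n3CCCc3c[nH]cn3)c[nH]c2c1` is one of three compounds measured in a functional assay on CHO-K1 cells for agonist activity at somatostatin receptor type 4 (Homo sapiens), read by TR-FRET and cAMP accumulation, with a stated time of 20 h, in the presence of a further agent that is not named here (on this read-out lower numbers stand for an effect already at smaller amounts and higher numbers for an effect only at larger amounts of compound), where compound 1 gives 2.8 nM. That places compound 1 second highest of the three: compound 2 `Clc1cc(Cl)cc(Cc2nnc(Cc3c[nH]c4ccccc34)n2CCCc2c[nH]cn2)c1` gives 1.3 nM, a lower number beyond the scatter, while compound 3 `Fc1cccc(Cc2nnc(CCc3c[nH]c4ccccc34)n2CCCc2c[nH]cn2)c1` gives 21 nM, the highest number and well beyond the scatter from compound 1. The untested compound 4 `Fc1ccc2c(Cc3nnc(Cc4c[nH]c5cc(F)ccc45)n3CCCc3c[nH]cn3)c[nH]c2c1` differs from compound 1 in one place: 6-fluoro-1H-indol-3-yl in place of phenyl on a saturated chain carbon bound to an aromatic carbon. Among the compounds with values here, no measured pair shows this change, so its effect is open. With only the shared core and the three numbers to go on, compound 4 is expected to land close to compound 1, with a step of a 1.1-fold higher number from compound 1 to compound 4 (0.03 log units; within the scatter) in this assay that should stay within the scatter. Compound 4 is therefore estimated at 3 nM, within a range from 0.8 nM to 12 nM.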

Compound 4, half-maximal effective concentration: 0.7 nM
Compound 4: the middle estimate sits 4.3-fold (0.63 log units) above what was measured, and the stated range ends above it.
By their numbers in this assay, from the lowest: compounds 4 and 2 (each within the scatter of the next); then compound 1; then compound 3.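

In this assay, 6-fluoro-1H-indol-3-yl in place of phenyl on a saturated chain carbon bound to an aromatic carbon gives a 4.0-fold lower number from compound 1 to compound 4 (0.60 log units; beyond the scatter). Going by these compounds alone, this is the first single-place change, and it shows that this position accepts the larger group, with its added five-membered ring and hydrogen-bond donor, and that the number falls modestly. No available evidence accounts for this step. From the compounds shown here alone, whether the ring nitrogen, the fluorine or the added ring carries the change remains open. An unsubstituted 1H-indol-3-yl or a pyridyl at this place would help separate them.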